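The source may report more compounds than this note shows. Statements on the series, on what has been measured and on what is new or still open speak of the compounds shown alone.

Of the compounds shown here, three built on a shared core have been tested in an ADME assay on J774.1 cells (Mus musculus) for cytotoxicity, read by MTT assay, with a stated time of 48 h; a higher number here means a weaker inhibitor, a lower number a stronger inhibitor. Compound 1, `Cc1c(C(=O)N/N=C/c2ccc([N+](=O)[O-])cc2)no[n+]1[O-]`, gives > 300000 nM in this assay, and that figure is a limit of the measurement rather than a number. Compound 2, `Cc1nc2ccccn2c1C(=O)N/N=C/c1no[n+]([O-])c1C`, gives > 400000 nM in this assay, and this too is only a limit. For the measured compounds named here, compound 3, `Cc1nc2ccccn2c1C(=O)N/N=C/c1c(-c2ccccc2)no[n+]1[O-]`, gives 56200 nM in this assay, the one value of the three that is an actual number. Going by the values given here, compound 1 therefore stands at the limit of > 300000 nM in this assay, at which 1 of the 3 values shown sits, so no step with a number leads away from it. The compound still to be measured is compound 4, `Cc1c(C(=O)N/N=C/c2ccc(C(=O)O)cc2)no[n+]1[O-]`, which differs from compound 1 in one place: carboxy in place of nitro on an aromatic carbon. Among the compounds with values here, no measured pair here differs in only one place, so the size of this step cannot be read off another pair. The expectation is that it stays within the scatter of this assay and points in no particular direction. The expected a number no higher from compound 1 to compound 4 (the limit leaves the size open) is therefore no change beyond the scatter. Compound 4 is accordingly estimated at 300000 nM in this assay, with a range from 100000 nM to 1000000 nM, and it may well come back as a limit again.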

Compound 4, half-maximal inhibitory concentration: > 300000 nM
Compound 4: only a limit was reported; the forecaster's own chance of this, stated with the estimate: 70%; the middle value lies on the limit itself.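

Compound 1 and compound 4 both return only a limit in this assay, not a number, so no step from one to the other can be read: the limit of > 300000 nM in this assay, at which 2 of the 4 values shown sit.

The compounds shown leave open whether carboxy in place of nitro on an aromatic carbon changes the value at all, and if so, in which direction.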